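Working notes: amide-nitrogen substituent swap in three measured compounds

The source may report more compounds than this note shows. Statements on the series, on what has been measured and on what is new or still open speak of the compounds shown alone.

Measured so far, in a functional assay on A549 cells (Homo sapiens) for antiproliferative activity, read by MTT assay, with a stated time of 72 h; a lower number here means a stronger inhibitor, a higher number a weaker inhibitor:
compound 1 `O=C1COc2ccc(-c3cnc(Cl)c(NS(=O)(=O)c4ccc(F)cc4)c3)cc2N1C1CCCCC1` gives 37900 nM
compound 2 `COc1ccc(N2C(=O)COc3ccc(-c4cnc(Cl)c(NS(=O)(=O)c5ccc(F)cc5)c4)cc32)cc1` gives 30400 nM
compound 3 `COc1ccc(N2C(=O)COc3ccc(-c4cccc(NS(=O)(=O)c5ccc(F)cc5)c4)cc32)cc1` gives 38200 nM

All three numbers lie within the usual scatter of one another, so no order among compound 1, compound 2 and compound 3 can be read from this assay.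

Compound 2 and compound 1 share one core and differ in a single place, (cyclohexyl in place of 4-methoxyphenyl on an amide-type nitrogen in a ring). The resulting step, a 1.2-fold higher number from compound 2 to compound 1 (0.10 log units; within the scatter), is within the scatter.

Compound 3 carries a different core; the difference between the core of compound 3 and the core of compound 2 is not broken down here.

Compound 4 `O=C1COc2ccc(-c3cccc(NS(=O)(=O)c4ccc(F)cc4)c3)cc2N1C1CCCCC1` has not yet been measured in this assay. It differs from compound 3 by cyclohexyl in place of 4-methoxyphenyl on an amide-type nitrogen in a ring, the same change already seen between compound 2 and compound 1, at a place described in identical terms.

An expectation for compound 4 therefore rests on a single precedent: the step of a 1.2-fold higher number from compound 2 to compound 1 (0.10 log units; within the scatter) stayed within the scatter, so the expected step is likewise small, a 1.1-fold higher number from compound 3 to compound 4 (0.04 log units; within the scatter).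

Compound 4 is expected to give 42000 nM in this assay, with a plausible range from 20000 nM to 90000 nM.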

Compound 4, half-maximal inhibitory concentration: 14500 nM
Compound 4: the middle estimate sits 2.9-fold (0.46 log units) above what was measured; measured number below the stated range.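

In this assay, cyclohexyl in place of 4-methoxyphenyl on an amide-type nitrogen in a ring gives a 2.6-fold lower number from compound 3 to compound 4 (0.42 log units; beyond the scatter), a modest step. The same change does not carry the same result from one core to the other: the same change on two cores in this assay, a 1.2-fold higher number (0.10 log units; within the scatter) from compound 2 to compound 1 and a 2.6-fold lower number (0.42 log units; beyond the scatter) from compound 3 to compound 4, 3.3-fold (0.52 log units) apart, beyond the scatter of two such steps

This shows that, for these two pairs, the outcome of the swap depends on the core it is made on, so the step seen on the core of compound 2 was no reliable guide for the core of compound 3; it does not show which feature of the cores separates the two results, and two pairs set no rule for any further core.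

From the compounds shown here alone, it remains open whether the gain on the core of compound 3 is particular to cyclohexyl or would also appear with another group on the amide-type nitrogen, such as a longer alkyl chain or a chain ending in an amine. Also open, going by these compounds, is how either core would respond to a carboxylic acid at that nitrogen.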